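The source may hold more compounds than are shown below. What is called first, only, known or untested is meant among the compounds shown, and "the series" means these compounds.

Three measured compounds share one core and differ only in the group attached to an amide-type nitrogen of a urea. Compound 1 `CN(C)C1(Cc2ccccc2)CCN(c2cc(C(F)(F)F)ccc2CNC(=O)Nc2cccc3ccc(O)cc23)CC1` in an assay on CHO cells for antagonist activity at transient receptor potential cation channel subfamily V member 1 (Homo sapiens), read by scintillation counting, with a stated time of 5 min, in the presence of a further agent that is not named here (a higher number here means that more compound is needed for the effect, a lower number that less compound is needed), gives 8.9 nM. Compound 2 `CN(C)C1(Cc2ccccc2)CCN(c2cc(C(F)(F)F)ccc2CNC(=O)Nc2cccc3c2CC(O)CC3)CC1` gives 10.1 nM in this assay, and compound 3 `CN(C)C1(Cc2ccccc2)CCN(c2cc(C(F)(F)F)ccc2CNC(=O)Nc2ccc3c(c2)OCC3)CC1` gives 31.3 nM. Compound 3 therefore has the highest number of the three, meaning more of it is needed than of either other compound: a 3.5-fold higher number from compound 1 to compound 3 (0.55 log units; beyond the scatter) and a 3.1-fold higher number from compound 2 to compound 3 (0.49 log units; beyond the scatter). Both steps point the same way: exchanging a group built from two fused six-membered rings for the smaller five-and-six-membered group raised the number by a modest but real amount.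

Compound 4 `CN(C)C1(Cc2ccccc2)CCN(c2cc(C(F)(F)F)ccc2CNC(=O)Nc2cccc3[nH]c(=O)ccc23)CC1` makes the reverse kind of move: a group of 11 heavy atoms (9 carbon, 1 nitrogen, 1 oxygen; one six-membered aromatic ring of carbon only, one six-membered aromatic ring with 1 hetero atom) in place of a group of 9 heavy atoms (8 carbon, 1 oxygen; one five-membered non-aromatic ring with 1 hetero atom, one six-membered aromatic ring of carbon only), on an amide-type nitrogen. The entering group again contains two fused six-membered rings, as in compound 1 and compound 2, and brings one hydrogen-bond donor with it. The two measured steps bear directly on this change, since both were modest rises when an 11-atom bicyclic group was lost. For compound 4 the expected step is accordingly a modest fall, a 2.8-fold lower number from compound 3 to compound 4 (0.45 log units; beyond the scatter). Compound 4 is thus estimated at 11 nM in this assay, with a likely range from 4 nM to 35 nM.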

Compound 4, half-maximal effective concentration: 30.6 nM
For compound 4 the middle estimate is 2.8-fold (0.44 log units) below the measured one, within the range that was stated.
By their numbers in this assay, from the lowest: compounds 1 and 2 (each within the scatter of the next); then compounds 4 and 3 (each within the scatter of the next).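

The step of a 1.0-fold lower number from compound 3 to compound 4 (0.01 log units; within the scatter) shows that restoring two fused six-membered rings on the amide-type nitrogen is not enough to lower the number, since the values of these two compounds cannot be told apart. The steps of a 3.0-fold higher number from compound 2 to compound 4 (0.48 log units; beyond the scatter) and a 3.4-fold higher number from compound 1 to compound 4 (0.54 log units; beyond the scatter) make the same point from the other side: the entering group has as many heavy atoms as the groups in compound 1 and compound 2 and also two fused six-membered rings, yet it does not match them, so ring count, ring size and heavy-atom count do not settle the number at this position among these four compounds. Nothing measured here explains why the group in compound 4 differs from those in compound 1 and compound 2.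

The compounds shown leave open whether the hydrogen-bond donor in the entering group matters, and a methyl group on the ring nitrogen of compound 4 would bear on that question. As far as these compounds go, it is also open whether an amine in place of the hydroxy group of the 7-hydroxynaphthalen-1-yl group in compound 1 would keep the number of compound 1 or move it towards that of compound 4.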